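This account rests on a few compounds, and the source may have more. Where it says the series, first, only, none or still open, it means among the compounds named here.

In a functional assay on MCF7 cells (Homo sapiens) for antiproliferative activity, read by MTT assay, with a stated time of 48 h (on this read-out lower numbers stand for stronger inhibition and higher numbers for weaker inhibition), compound 1 (`Cc1ccc2[nH]c(-c3cn(-c4ccccc4)nc3-c3ccccc3)nc2c1`) gives 5940 nM and compound 2 (`COc1ccc2[nH]c(-c3cn(-c4ccccc4)nc3-c3ccc(F)cc3)nc2c1`) gives 970 nM as the lower of the two numbers, apart from compound 1 by more than the scatter. Compound 3 (`Cc1ccc2[nH]c(-c3cn(-c4ccccc4)nc3-c3ccc(F)cc3)nc2c1`) carries methyl in place of methoxy on an aromatic carbon of compound 2 (methyl in place of methoxy on an aromatic carbon). Going by the values given here, no measured pair shows this change alone. Compound 1 also carries methyl and gives 5940 nM but differs from compound 2 in a second place too, so only a moderate rise in this assay is expected, with a 2.5-fold higher number from compound 2 to compound 3 (0.39 log units; beyond the scatter) as the estimated step. For compound 3 the estimated value is 2400 nM (range 900 nM to 6000 nM).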

Compound 3, half-maximal inhibitory concentration: 1120 nM
For compound 3 the middle estimate is 2.1-fold (0.33 log units) above the measured one, and the stated range covers the measured number.
By their numbers in this assay, from the lowest: compounds 2 and 3 (each within the scatter of the next); then compound 1.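

In this assay the step of a 1.2-fold higher number from compound 2 to compound 3 (0.06 log units; within the scatter) puts methoxy and methyl on this aromatic carbon within the scatter of each other, so this change alone does not separate compound 2 from compound 3. The step that does stand out lies at the other place: with methyl kept, fluoro in place of hydrogen on an aromatic carbon gives a 5.3-fold lower number from compound 1 to compound 3 (0.72 log units; beyond the scatter) in this pair.

Going by these compounds, whether this aromatic carbon also accepts an amine, a carboxylic acid or a longer chain stays open, as does whether the fluoro step holds with methoxy in place of methyl. No measurement on hand gives a reason for either step.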